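One Ring Swap on a Shared Core

The compounds below may be only part of what the source reports. "The series", "measured", "known", "first", "only" and "open" are said of these compounds alone.

In a functional assay on CNE-2 cells (Homo sapiens) for antiproliferative activity, read by sulforhodamine B assay, with a stated time of 48 h (a lower number here means a stronger inhibitor, a higher number a weaker inhibitor), compound 1 `COc1cccc(/C=C/C(=O)C(=Cc2cc(OC)c(OC)c(OC)c2)C(=O)/C=C/c2cccc(OC)c2OC)c1OC` gives 400 nM and compound 2 `COc1cc(C=C(C(=O)/C=C/c2cccc(OC)c2OC)C(=O)/C=C/c2cccc(OC)c2OC)cc(Br)c1O` gives 220 nM on the shared core. These two numbers cannot be told apart, since the measured step is a 1.8-fold lower number from compound 1 to compound 2 (0.26 log units; within the scatter) and so neither compound leads.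

That step changed only the ring group on a double-bonded chain carbon bound to a double-bonded chain carbon. Compound 3 `COc1cccc(/C=C/C(=O)C(=Cc2ccc(OC)c(OC)c2OC)C(=O)/C=C/c2cccc(OC)c2OC)c1OC` differs from compound 2 at that same place, where the difference is 2,3,4-trimethoxyphenyl in place of 3-bromo-4-hydroxy-5-methoxyphenyl on a double-bonded chain carbon bound to a double-bonded chain carbon and 2,3,4-trimethoxyphenyl stands in place of 3-bromo-4-hydroxy-5-methoxyphenyl.

Among the compounds with values here, the one measured step is the only guide to size, and it stayed within the scatter. Compound 1 also carries a trimethoxyphenyl group there and gives 400 nM as the closest available comparison for compound 3. The expected change is a 1.5-fold higher number from compound 2 to compound 3 (0.16 log units; within the scatter) in this assay and this is no real shift beyond the scatter. Compound 3 is estimated at 320 nM with an expected range of 130 nM to 800 nM until it is measured.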

Compound 3, half-maximal inhibitory concentration: 410 nM
Compound 3: middle estimate off by 1.3-fold (0.11 log units), on the low side; low and high end bracket the measured number.
By their numbers in this assay, from the lowest: compounds 2, 1 and 3 (each within the scatter of the next).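

Both new steps stay within the scatter in this assay: a 1.9-fold higher number from compound 2 to compound 3 (0.27 log units; within the scatter), and a 1.0-fold higher number from compound 1 to compound 3 (0.01 log units; within the scatter). The second step adds something the first could not show, since 2,3,4-trimethoxyphenyl and 3,4,5-trimethoxyphenyl carry the same three methoxy groups in different arrangements on the ring, and this rearrangement on a double-bonded chain carbon bound to a double-bonded chain carbon leaves the two numbers indistinguishable. Across compounds 1, 2 and 3, then, neither rearranging the methoxy groups nor exchanging 3-bromo-4-hydroxy-5-methoxyphenyl for a trimethoxyphenyl group gives a difference that can be told from the scatter, and no other kind of measurement is available to explain this.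

Going by these compounds, all three groups at this place are phenyl rings bearing methoxy groups, so it remains open whether a ring carrying an amine or a carboxylic acid, or a longer chain in place of the ring, would give a number beyond the scatter. On these data alone, the rest of the shared core is the same in all three compounds, so the effect of changes elsewhere on it also remains open.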